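The source may report more compounds than this note shows. Statements on the series, on what has been measured and on what is new or still open speak of the compounds shown alone.

Measured compounds:
compound 1, `COc1ccc(F)cc1CNCCCNc1ccnc2cc(CC3CCCCC3)ccc12`: 1830 nM
compound 2, `COc1ccc(F)cc1CNCCCNc1ccnc2cc(CCc3ccccc3)ccc12`: 4240 nM
compound 3, `COc1cccc(CNCCCNc2ccnc3cc(CCc4ccccc4)ccc23)c1O`: 6800 nM

All three were run in an ADME assay on HepG2 cells (Homo sapiens) for cytotoxicity, read by luminescence, CellTiter-Glo and ATP content, with a stated time of 72 h; on this read-out higher numbers stand for an effect only at larger amounts of compound and lower numbers for an effect already at smaller amounts. Compound 2 is the point of comparison for the set. Going from compound 2 to compound 1 the change is cyclohexyl in place of benzyl on a saturated chain carbon bound to an aromatic carbon and it gives a 2.3-fold lower number from compound 2 to compound 1 (0.36 log units; beyond the scatter). Going from compound 2 to compound 3 the two cores differ by 2-hydroxy-3-methoxyphenyl in place of 5-fluoro-2-methoxyphenyl on a saturated chain carbon bound to an amine nitrogen, with a 1.6-fold higher number from compound 2 to compound 3 (0.21 log units; within the scatter), so compound 2 and compound 3 cannot be told apart on this read-out.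

Compound 4, `COc1cccc(CNCCCNc2ccnc3cc(CC4CCCCC4)ccc23)c1O`, has not yet been measured in this assay. Relative to compound 3 it carries cyclohexyl in place of benzyl on a saturated chain carbon bound to an aromatic carbon. This is the same change as that from compound 2 to compound 1, made on the other core; the place is the same in both cases. For the measured compounds named here, the one measured instance of the change is a 2.3-fold lower number from compound 2 to compound 1 (0.36 log units; beyond the scatter), a modest step that lies beyond the scatter. Nothing else in the set bears on how the change behaves on the core of compound 3, so the expectation for compound 4 rests on that single step alone.

Going by the values given here, for compound 4 the step from compound 3 is estimated as a 2.3-fold lower number from compound 3 to compound 4 (0.36 log units; beyond the scatter), because a 2.3-fold lower number from compound 2 to compound 1 (0.36 log units; beyond the scatter) is the only precedent. Compound 4 is therefore expected to fall near 3000 nM in this assay, with a range from 1500 nM to 6000 nM.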

Compound 4, half-maximal effective concentration: 970 nM
Estimate against measurement, compound 4: 3.1-fold (0.49 log units) above; the measured number lies below the stated range.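

In this assay, cyclohexyl in place of benzyl gives a lower number on both cores, with a 7.0-fold lower number from compound 3 to compound 4 (0.85 log units; beyond the scatter), so the direction of the change carries from one core to the other while its size does not: the same change on two cores in this assay, a 2.3-fold lower number (0.36 log units; beyond the scatter) from compound 2 to compound 1 and a 7.0-fold lower number (0.85 log units; beyond the scatter) from compound 3 to compound 4, 3.0-fold (0.48 log units) apart, beyond the scatter of two such steps. Read the other way round the same four compounds, 2-hydroxy-3-methoxyphenyl in place of 5-fluoro-2-methoxyphenyl gives a 1.9-fold lower number from compound 1 to compound 4 (0.28 log units; within the scatter), a step that is small by itself, yet the two steps of this change do not match either: the same change on two cores in this assay, a 1.6-fold higher number (0.21 log units; within the scatter) from compound 2 to compound 3 and a 1.9-fold lower number (0.28 log units; within the scatter) from compound 1 to compound 4, 3.0-fold (0.48 log units) apart, beyond the scatter of two such steps. The two changes are therefore not additive in these compounds, but a single set of four shows neither the cause of the mismatch nor whether a step measured on one core can be applied to a core outside this set.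

Going by these compounds, whether the mismatch persists with cyclopentyl in place of cyclohexyl, or with a longer chain carrying the amine, remains open. Also open, on these data alone, is whether a third group in place of 2-hydroxy-3-methoxyphenyl, such as a pyridine ring, would follow the core of compound 1 or the core of compound 3 in the size of the step.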